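Replacing the 4-(tert-butyl)phenyl group of compound 3

The source may report more compounds than this note shows. Statements on the series, on what has been measured and on what is new or still open speak of the compounds shown alone.

Measured so far in a functional assay on A2780 cells (Homo sapiens) for inhibition, read by MTT assay, with a stated time of 72 h; a higher number here means a weaker inhibitor, a lower number a stronger inhibitor
Compound 1 `O=C1/C(=C\c2ccccc2)c2c(ncn2COCc2ccccc2)CCN1Cc1ccc(F)cc1` gives 24800 nM
Compound 2 `O=C1/C(=C\c2ccccc2)c2c(ncn2COCc2ccccc2)CCN1Cc1ccc(-c2ccccc2)cc1` gives 48300 nM
Compound 3 `CC(C)(C)c1ccc(CN2CCc3ncn(COCc4ccccc4)c3/C(=C/c3ccccc3)C2=O)cc1` gives 23900 nM

Compound 3 cannot be told apart from one neighbour (a 1.0-fold lower number from compound 1 to compound 3 (0.02 log units; within the scatter)) and stands modestly apart from the other (a 2.0-fold lower number from compound 2 to compound 3 (0.31 log units; beyond the scatter)). Compound 4 `O=C1/C(=C\c2ccccc2)c2c(ncn2COCc2ccccc2)CCN1Cc1ccc2ccccc2c1` differs from compound 3 by naphthalen-2-yl in place of 4-(tert-butyl)phenyl on a saturated chain carbon bound to an amide-type nitrogen in a ring and so carries naphthalen-2-yl in place of 4-(tert-butyl)phenyl. For the measured compounds named here, no measured step makes this exchange. The nearest guides are swaps on an aromatic carbon of that same substituent, one within the scatter (a 1.9-fold higher number from compound 1 to compound 2 (0.29 log units; within the scatter)) and the largest only just beyond it (a 2.0-fold lower number from compound 2 to compound 3 (0.31 log units; beyond the scatter)). A slightly higher number, no step beyond the scatter, is therefore expected in this assay (a 1.3-fold higher number from compound 3 to compound 4 (0.10 log units; within the scatter)). The expected value for compound 4 is 30000 nM as an estimate, with a range from 14000 nM to 60000 nM for it.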

Compound 4, half-maximal inhibitory concentration: 72800 nM
Compound 4: the middle estimate sits 2.4-fold (0.39 log units) below what was measured; the measured number lies above the stated range.
By their numbers in this assay, from the lowest: compounds 3, 1, 2 and 4 (each within the scatter of the next, the first and the last beyond it).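

In (this assay), naphthalen-2-yl, with two six-membered aromatic rings, gives weaker inhibition on this saturated chain carbon than either 4-(tert-butyl)phenyl (a 3.0-fold higher number from compound 3 to compound 4 (0.48 log units; beyond the scatter)) or 4-fluorophenyl (a 2.9-fold higher number from compound 1 to compound 4 (0.47 log units; beyond the scatter)), each with one ring. Against 4-phenylphenyl, which also has a second aromatic ring, the step stays within the scatter (a 1.5-fold higher number from compound 2 to compound 4 (0.18 log units; within the scatter)). A second ring therefore tends to go with weaker inhibition here, although compound 2 stays within the scatter of compound 1, which goes against this pattern. Nothing available explains this difference.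

The compounds shown leave open how a saturated cyclohexyl group or a benzyl group carrying an amine or a carboxylic acid would behave at this position.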